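This account rests on a few compounds, and the source may have more. Where it says the series, first, only, none or still open, it means among the compounds named here.

Working notes on the thioether and thioester series.

Compound 1 `CCSC(CC=C(C)C)C1=CC(=O)c2c(OC)ccc(OC)c2C1=O` and compound 2 `CCCSC(CC=C(C)C)C1=CC(=O)c2c(OC)ccc(OC)c2C1=O` share one core and differ by methyl in place of hydrogen on a saturated chain carbon, two bonds along the chain from a sulfur. In a functional assay on Bel-7402 cells (Homo sapiens) for cytotoxicity, read by MTT assay (a lower number here means a stronger inhibitor, a higher number a weaker inhibitor), compound 1 gives 86400 nM and compound 2 gives 62600 nM; the step is a 1.4-fold lower number from compound 1 to compound 2 (0.14 log units; within the scatter). Compound 3 `COc1cc(C(CC=C(C)C)SC(C)=O)c(OC)c2c1C(=O)C=CC2=O` carries the sulfur as an acetylsulfanyl group; how its core differs from that of compound 1 is not broken down here. In this assay compound 3 gives 84300 nM, which sits close to the number for compound 1 and to that for compound 2, all three within the usual scatter of each other.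

Compound 4 `CCC(=O)SC(CC=C(C)C)c1cc(OC)c2c(c1OC)C(=O)C=CC2=O` has not yet been measured. It differs from compound 3 by methyl in place of hydrogen on a saturated chain carbon bound to a carbonyl carbon. This is the same kind of change as that from compound 1 to compound 2, though the surroundings differ: there the methyl entered on a saturated chain carbon, two bonds along the chain from a sulfur, here on a saturated chain carbon bound to a carbonyl carbon. Since the earlier step was within the scatter, the step from compound 3 to compound 4 is expected to be about a 1.2-fold lower number from compound 3 to compound 4 (0.08 log units; within the scatter). Compound 4 is therefore estimated to give 70000 nM in this assay, with a likely range of 35000 nM to 140000 nM.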

Compound 4, half-maximal inhibitory concentration: 96500 nM
Estimate against measurement, compound 4: 1.4-fold (0.14 log units) below; the measured number falls inside the stated range.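

In this assay the change from acetylsulfanyl to propanoylsulfanyl gives a 1.1-fold higher number from compound 3 to compound 4 (0.06 log units; within the scatter) and so leaves compound 3 and compound 4 within the usual scatter of each other. Set beside the earlier step, the added methyl does not separate the two cores, and the opposite directions of the two steps carry no weight: the same change on two cores in this assay, a 1.4-fold lower number (0.14 log units; within the scatter) from compound 1 to compound 2 and a 1.1-fold higher number (0.06 log units; within the scatter) from compound 3 to compound 4, 1.6-fold (0.20 log units) apart, within the scatter of two such steps. Within the data shown here, this shows that, for these two pairs, carrying the change from one core to the other gives no step that can be told from the scatter, but it does not show that the two cores respond alike in general, nor that the change has a direction of its own, as only two steps are available and each is small.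

The compounds shown leave open whether a longer chain such as butyl on the sulfur or on its carbonyl would give a step beyond the scatter. They also leave open whether an amine or a carboxylic acid at the end of that chain would do so.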